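A few compounds are considered here, and "the series" means these few. Any claim that something is new, unique, unknown or untested is made for them only; others in the source may bear on it.

Measured compounds in an assay on isolated protein for activation of cGMP-dependent protein kinase 1 (Homo sapiens), read by ADP-Glo, with stated times of 120 min and 40 min; a higher number here means that more compound is needed for the effect, a lower number that less compound is needed:

- compound 1, `Clc1cc(Cl)cc(CO[C@H]2CCCN(Cc3ccccc3)[C@H]2c2ccccc2)c1`, gives > 200000 nM; this is a limit of this assay, not a number.
- compound 2, `O=C(O)c1cncc(CN2CCC[C@H](OCc3cc(Cl)cc(Cl)c3)[C@@H]2c2ccccc2)c1`, gives 117000 nM.
- compound 3, `Clc1cc(Cl)cc(CO[C@H]2CCCN(Cc3nccs3)[C@H]2c2ccccc2)c1`, gives > 200000 nM; this too is a limit of this assay.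
- compound 4, `Clc1cc(Cl)cc(CO[C@H]2CCCN(Cc3cccnc3)[C@H]2c2ccccc2)c1`, is not yet measured.

Compound 3 thus stands at the limit, where (the limit of > 200000 nM in this assay, at which 2 of the 3 values shown sit). The change to compound 4 is pyridin-3-yl in place of 1,3-thiazol-2-yl on a saturated chain carbon bound to an amine nitrogen in a ring. For the measured compounds named here, three measured steps touch this position. The step that the two limits leave unreadable from compound 1 to compound 3 is unreadable. The step of an at least 1.7-fold higher number from compound 2 to compound 3 (0.23 log units; that floor lies within the scatter) is a floor within the scatter. The step of an at least 1.7-fold lower number from compound 1 to compound 2 (0.23 log units; that floor lies within the scatter) is likewise a floor within the scatter. Going by the values given here, every measured value in this assay is either a limit or close to it, and no step is resolved beyond the scatter, so the size of the present step cannot be read from the data. The expected step of a number no higher from compound 3 to compound 4 (the limit leaves the size open) is therefore none beyond the scatter, with a limit the most likely outcome. Compound 4 is estimated at 200000 nM, with a range from 90000 nM to 450000 nM.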

Compound 4, half-maximal effective concentration: 112000 nM
Estimate against measurement, compound 4: 1.8-fold (0.25 log units) above; the range from low to high includes it.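

In this assay the step with hydrogen in place of carboxy on an aromatic carbon is a 1.0-fold lower number from compound 2 to compound 4 (0.02 log units; within the scatter) and so gives no sign that the carboxy group matters here. Compound 4 shows that a readable number at this position does not depend on that group. With pyridin-3-yl in place of 1,3-thiazol-2-yl the result is an at least 1.7-fold lower number from compound 3 to compound 4 (0.25 log units; that floor lies within the scatter) and with pyridin-3-yl in place of phenyl it is an at least 1.7-fold lower number from compound 1 to compound 4 (0.25 log units; that floor lies within the scatter), so both steps remain floors that do not establish a gain for pyridin-3-yl.

Open, on these data alone, is whether any change at this place gives a step beyond the scatter. Pyridin-4-yl, or a primary amine or an amide in place of the carboxy group, would test how far this position can move the number.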